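The compounds below may be only part of what the source reports. "The series", "measured", "known", "first", "only" and "open" are said of these compounds alone.

Measured so far in a functional assay on A549 cells (Homo sapiens) for inhibition, read by CCK-8 assay, with a stated time of 72 h, tested at 8 uM (on this read-out higher numbers stand for more inhibition of growth at the one concentration tested and lower numbers for less inhibition of growth), across three compounds:

Compound 1 `CCc1ccc(SCc2ccc(C(=O)Nc3ccccc3N)cc2)cc1` gives 91.4%
Compound 2 `Cc1ccc(SCc2ccc(/C=C/C(=O)Nc3ccccc3N)cc2)cc1` gives 48.3%
Compound 3 `Nc1ccccc1NC(=O)/C=C/c1ccc(CSc2cccc3ccccc23)cc1` gives 71.2%

Compound 1 stands highest of the three, and its lead over both compound 2 and compound 3 lies beyond the scatter. Compound 4 `Nc1ccccc1NC(=O)c1ccc(CSc2ccc(F)cc2)cc1` keeps the core of compound 1 and changes a single group: fluoro in place of ethyl on an aromatic carbon. This is 4-ethylphenyl to 4-fluorophenyl, with fluoro in place of ethyl on an aromatic carbon.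

Going by the values given here, only one measured step bears on this change. That step, a number 22.9 percentage points higher from compound 2 to compound 3 (beyond the scatter), is modest but beyond the scatter. It came with naphthalen-1-yl in place of 4-methylphenyl on a sulfur, so it too alters the aromatic group on sulfur. However, compound 2 and compound 3 also differ from compound 1 elsewhere, their swap is much larger than ethyl to fluoro, and no measured compound carries fluoro. A smaller step is therefore expected here. With compound 1 already at 91.4% there is little room upward, so a slight fall is expected, possibly none beyond the scatter. The estimated step is a number 9.4 percentage points lower from compound 1 to compound 4 (within the scatter) in this reading. Compound 4 is expected at 82% with an estimated range from 62% to 95% in this assay when measured.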

Compound 4, percent growth inhibition at one concentration: 44.5%
Beside the measured number, compound 4's estimate is 37.5 percentage points above it, outside the stated range (below it).
By their numbers in this assay, from the lowest: compounds 4 and 2 (each within the scatter of the next); then compound 3; then compound 1.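

In this assay, the step of a number 46.9 percentage points lower from compound 1 to compound 4 (beyond the scatter) shows that the aromatic carbon para to a large group is far from indifferent to what it carries: on the core of compound 1, fluoro in place of ethyl is a small exchange of groups, yet the step it brings is large and beyond the scatter. Going by these compounds alone, the only earlier step touching this aromatic group, a number 22.9 percentage points higher from compound 2 to compound 3 (beyond the scatter), exchanged 4-methylphenyl for the whole naphthalen-1-yl group and went upward, so it gave no sign that one group on an otherwise unchanged 4-substituted phenyl could bring a fall of this size. No measurement available here accounts for the result.

The compounds shown do not tell whether this step reflects the loss of ethyl or the arrival of fluoro, and a chloro, methoxy or propyl group at the same place on the core of compound 1 would help separate the two. They also leave open whether fluoro in place of methyl would move compound 2 in the same direction.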